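This account rests on a few compounds, and the source may have more. Where it says the series, first, only, none or still open, it means among the compounds named here.

Compound 1 `O=C1O[C@H]([C@@H](O)Cn2cc(-c3ccc(Br)cc3)nn2)C(OCc2ccccc2)=C1OCc1ccccc1` gives 750 nM in a functional assay on A549 cells (Homo sapiens) for antiproliferative activity, read by MTT assay, with a stated time of 72 h (a lower number here means a stronger inhibitor, a higher number a weaker inhibitor), the lowest of the three numbers measured. Compound 2 `O=C1O[C@H]([C@@H](O)Cn2cc(CNS(=O)(=O)c3ccc(F)cc3)nn2)C(OCc2ccccc2)=C1OCc1ccccc1`, which bears a (((4-fluorophenyl)sulfonyl)amino)methyl in place of the 4-bromophenyl, gives 22500 nM, and compound 3 `CC(C)(C)c1cn(C[C@H](O)[C@H]2OC(=O)C(OCc3ccccc3)=C2OCc2ccccc2)nn1`, which bears a tert-butyl there instead, gives 34000 nM. Both steps away from compound 1 are large: a 30-fold higher number from compound 1 to compound 2 (1.48 log units; beyond the scatter) and a 45-fold higher number from compound 1 to compound 3 (1.66 log units; beyond the scatter), while a 1.5-fold higher number from compound 2 to compound 3 (0.18 log units; within the scatter).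

Compound 4 `COc1ccc(-c2cn(C[C@H](O)[C@H]3OC(=O)C(OCc4ccccc4)=C3OCc3ccccc3)nn2)cc1` differs from compound 1 in one place: methoxy in place of bromo on an aromatic carbon. Within the data shown here, neither measured step bears directly on this change; both removed the whole 4-bromophenyl rather than exchanging its substituent, and no measured pair varies a group on that aryl. Since compound 4 keeps the aryl group that distinguishes compound 1 from compounds 2 and 3, a step no larger than the scatter is expected for compound 4, a 1.6-fold higher number from compound 1 to compound 4 (0.20 log units; within the scatter). Compound 4 is therefore estimated at 1200 nM, within a range of 400 nM to 4000 nM.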

Compound 4, half-maximal inhibitory concentration: 28300 nM
For compound 4 the middle estimate is 24-fold (1.37 log units) below the measured one, and the stated range ends below it.
By their numbers in this assay, from the lowest: compound 1; then compounds 2, 4 and 3 (each within the scatter of the next).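

Exchanging bromo for methoxy while keeping the phenyl ring is enough to produce a large step (a 38-fold higher number from compound 1 to compound 4 (1.58 log units; beyond the scatter)), so in this assay the presence of an aryl group at this position does not by itself account for the low number of compound 1; the substituent on that ring matters. The 4-methoxyphenyl group stands level with both non-aryl-bearing groups, tert-butyl (a 1.2-fold lower number from compound 3 to compound 4 (0.08 log units; within the scatter)) and (((4-fluorophenyl)sulfonyl)amino)methyl (a 1.3-fold higher number from compound 2 to compound 4 (0.10 log units; within the scatter)), leaving 4-bromophenyl alone apart among the four compounds. No measurement available here explains the gap between bromo and methoxy.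

On these data alone, it remains open whether the low number is particular to bromo or would also appear with chloro, iodo, methyl or an amine in the same place. Whether the unsubstituted phenyl group sides with 4-bromophenyl or with 4-methoxyphenyl is also unsettled.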